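The compounds below may be only part of what the source reports. "The series", "measured", "known", "first", "only" and "open" are said of these compounds alone.

Measured compounds and their values:
- Compound 1 `COc1ccc(-c2cc(COC(Cc3cn(C4CCN(Cc5ccc([N+](=O)[O-])cc5)CC4)nn3)c3ccc(Br)cc3)on2)cc1`: 2000 nM
- Compound 2 `O=[N+]([O-])c1ccc(CN2CCC(n3cc(CC(OCc4cc(-c5cccc(Br)c5)no4)c4ccc(Br)cc4)nn3)CC2)cc1`: 3000 nM

In a functional assay on Huh-7 cells (Homo sapiens) for cytotoxicity, with a stated time of 48 h (on this read-out lower numbers stand for stronger inhibition and higher numbers for weaker inhibition), compound 2 gives 3000 nM, the higher of the two numbers recorded, and its nearest neighbour is compound 1 with 2000 nM. Among the compounds with values here, the only step between them, a 1.5-fold higher number from compound 1 to compound 2 (0.18 log units; within the scatter), came from swapping 3-bromophenyl for 4-methoxyphenyl on an aromatic carbon, and that swap did not move the read-out beyond the usual spread of repeated runs.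

Compound 3 `N#Cc1cccc(-c2cc(COC(Cc3cn(C4CCN(Cc5ccc([N+](=O)[O-])cc5)CC4)nn3)c3ccc(Br)cc3)on2)c1` is the next point on the same ring. It differs from compound 2 by cyano in place of bromo on an aromatic carbon. Within the data shown here, the one measured step that bears on it, a 1.5-fold higher number from compound 1 to compound 2 (0.18 log units; within the scatter), also altered the group on this aromatic ring and stayed within the scatter, so there is no sign so far that changes at this position move the number much. On that basis compound 3 is expected to sit close to compound 2, with a step of no change at the digits printed from compound 2 to compound 3 (within the scatter) that is not expected to exceed the scatter. The estimate for compound 3 in this assay is 3000 nM, within a range from 1200 nM to 7500 nM.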

Compound 3, half-maximal inhibitory concentration: 3000 nM
For compound 3 middle estimate and measured number coincide at the digits printed; low and high end bracket the measured number.
By their numbers in this assay, from the lowest: compounds 1, 2 and 3 (each within the scatter of the next).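

In this assay, setting cyano in place of bromo on the six-membered aromatic ring, meta to a large group, gives no change at the digits printed from compound 2 to compound 3 (within the scatter). This step brings in a triple bond and a hydrogen-bond acceptor, neither of which the bromo group has, yet the number stays within the scatter, and replacing 4-methoxyphenyl with 3-cyanophenyl likewise gives a 1.5-fold higher number from compound 1 to compound 3 (0.18 log units; within the scatter), so all three compounds now read alike despite three different aromatic groups at this position. There is no supporting measurement that could explain why these changes leave the read-out so flat.

The compounds shown leave open whether any group on this ring can move the number beyond the scatter, since all three values lie within it and so give no trend to follow. An amine, a carboxylic acid or a longer chain in this place would test that question, and a result beyond the scatter would show that this position can affect the read-out after all.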